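Aryl variation on the shared core: the nitro step

This account rests on a few compounds, and the source may have more. Where it says the series, first, only, none or still open, it means among the compounds named here.

Compound 1 `C=CCOc1cc(OC)c(C(=O)/C=C/c2ccccc2)c(OCC=C)c1` carries a phenyl on the double-bonded chain carbon bound to a double-bonded chain carbon. For the measured compounds named here, in an ADME assay on Vero cells (Chlorocebus sabaeus) for cytotoxicity, read by MTT assay (on this read-out higher numbers stand for weaker inhibition and lower numbers for stronger inhibition), compound 1 gives 17100 nM, the second highest of the three numbers measured so far. Compound 2 `C=CCOc1cc(OC)c(C(=O)/C=C/c2ccncc2)c(OCC=C)c1`, with pyridin-4-yl in place of phenyl, gives 2800 nM in this assay; the step is a 6.1-fold lower number from compound 1 to compound 2 (0.79 log units; beyond the scatter). Compound 3 `C=CCOc1cc(OC)c(C(=O)/C=C/c2ccco2)c(OCC=C)c1`, with furan-2-yl in place of phenyl, gives 191000 nM in this assay, and the step is an 11-fold higher number from compound 1 to compound 3 (1.05 log units; beyond the scatter). Between those two compounds, a 68-fold higher number from compound 2 to compound 3 (1.83 log units; beyond the scatter).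

Compound 4 `C=CCOc1cc(OC)c(C(=O)/C=C/c2ccc([N+](=O)[O-])cc2)c(OCC=C)c1` differs from compound 1 by nitro in place of hydrogen on an aromatic carbon. Both measured steps replace the aryl group as a whole, whereas compound 4 keeps the phenyl and adds a group on it, so they bear on this step only loosely. What they do show is that changes at this end of the chain move the number in this assay in either direction and well beyond the scatter. Going by the values given here, with no closer precedent, the expected step is a 1.4-fold lower number from compound 1 to compound 4 (0.15 log units; within the scatter), small against those seen, with wide bounds. Compound 4 is therefore estimated at 12000 nM in this assay, between 3000 nM and 60000 nM.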

Compound 4, half-maximal inhibitory concentration: 12600 nM
Beside the measured number, compound 4's estimate is 1.1-fold (0.02 log units) below it; the measured number falls inside the stated range.
By their numbers in this assay, from the lowest: compound 2; then compounds 4 and 1 (each within the scatter of the next); then compound 3.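

Adding nitro to the phenyl, para to a large group, is the first change at this end of the chain whose step in this assay stays within the scatter, with a 1.4-fold lower number from compound 1 to compound 4 (0.13 log units; within the scatter). Compound 4 keeps its phenyl, and the steps that replace its whole aryl group remain beyond the scatter, with a 15-fold lower number from compound 3 to compound 4 (1.18 log units; beyond the scatter) and a 4.5-fold higher number from compound 2 to compound 4 (0.65 log units; beyond the scatter); among the compounds shown, only swapping the aryl group as a whole has moved the number beyond the scatter, and the one substitution on the phenyl has not. No measurement at hand accounts for the size of the nitro step or for the order of the aryl groups.

One substituent cannot show whether this tolerance is general, so an amine, a carboxylic acid or a longer chain on the same aromatic carbon could behave quite differently. On these data alone, it also remains open whether nitro elsewhere on the phenyl would give a similar step, and whether a substituent on pyridin-4-yl or furan-2-yl would stay as close to its parent compound.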